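Dichlorophenyl to dimethoxyphenyl: notes on the series

This account rests on a few compounds, and the source may have more. Where it says the series, first, only, none or still open, it means among the compounds named here.

In a functional assay on CCRF-CEM cells (Homo sapiens) for antiproliferative activity, with a stated time of 72 h (on this read-out higher numbers stand for weaker inhibition and lower numbers for stronger inhibition), compound 1 `OC[C@H]1O[C@@H](n2cnc3c(NCc4ccccc4F)ncnc32)[C@H](O)[C@@H]1O` gives 4600 nM, compound 2 `OC[C@H]1O[C@@H](n2cnc3c(NCc4ccccc4Br)ncnc32)[C@H](O)[C@@H]1O` gives 12300 nM and compound 3 `OC[C@H]1O[C@@H](n2cnc3c(NCc4ccc(Cl)cc4Cl)ncnc32)[C@H](O)[C@@H]1O` gives 86700 nM, the highest number of the three and so the weakest inhibition. Compound 4 `COc1ccc(CNc2ncnc3c2ncn3[C@@H]2O[C@H](CO)[C@@H](O)[C@H]2O)c(OC)c1` differs from compound 3 as follows: 2,4-dimethoxyphenyl in place of 2,4-dichlorophenyl on a saturated chain carbon bound to a nitrogen on an aromatic ring. That is, 2,4-dimethoxyphenyl stands in place of 2,4-dichlorophenyl on a saturated chain carbon bound to a nitrogen on an aromatic ring. Within the data shown here, no measured step makes this exact exchange. The nearest evidence is a 7.0-fold higher number from compound 2 to compound 3 (0.85 log units; beyond the scatter) and a 19-fold higher number from compound 1 to compound 3 (1.28 log units; beyond the scatter), with a 2.7-fold higher number from compound 1 to compound 2 (0.43 log units; beyond the scatter) as a smaller step. All three show that the number responds to changes on this aromatic ring. A modest expected step toward stronger inhibition in this assay is a 2.9-fold lower number from compound 3 to compound 4 (0.46 log units; beyond the scatter). For compound 4 the estimate is 30000 nM, with an expected range of 9000 nM to 90000 nM.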

Compound 4, half-maximal inhibitory concentration: > 166000 nM
Compound 4: only a limit was reported (the forecaster's own chance of this, stated with the estimate: 10%); middle value at least 5.5-fold (0.74 log units) from the limit.
By their numbers in this assay, from the lowest: compound 1; then compound 2; then compound 3. At a limit, above all of these: compound 4.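

In this assay compound 4 gives only a limit, not a number: the limit of > 166000 nM in this assay, at which 1 of the 4 values shown sits.

The step of an at least 1.9-fold higher number from compound 3 to compound 4 (0.28 log units; that floor lies within the scatter) has a floor that does not separate the two 2,4-disubstituted rings, so exchanging chlorine for methoxy brings no recovery here. Both an at least 13-fold higher number from compound 2 to compound 4 (1.13 log units; beyond the scatter) and an at least 36-fold higher number from compound 1 to compound 4 (1.55 log units; beyond the scatter) extend to a non-halogen group what compound 3 suggested: among these four, the 2,4-disubstituted rings give the weaker inhibition.

Going by these compounds, the true number for compound 4 remains open, as does its order relative to compound 3. On these data alone, it is also open whether a phenyl ring carrying an amine would follow this trend.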